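A Methyl for a Fluorine on One Aromatic Ring

The source may report more compounds than this note shows. Statements on the series, on what has been measured and on what is new or still open speak of the compounds shown alone.

Three compounds share one core and differ only in one aromatic ring. Compound 1 `O=C1/C(=C/c2ccccc2)CCC/C1=C\c1ccc(F)cc1` carries a 4-fluorophenyl group, and in an assay on isolated protein for inhibition of Alpha glucosidase (Homo sapiens), with stated times of 5 min and 15 min, tested at 50 uM (on this read-out higher numbers stand for more inhibition at the one concentration tested (going by the name of the read-out) and lower numbers for less inhibition), compound 1 gives 34%. Compound 2 `O=C1/C(=C/c2ccccc2)CCC/C1=C\c1ccc(F)c(F)c1` gives 37.8%, while compound 3 `COc1ccc(/C=C2\CCC/C(=C\c3ccccc3)C2=O)cc1` gives 31.4%. Compound 1 stands second highest of these three numbers, but the spread is small: the step of a number 3.8 percentage points higher from compound 1 to compound 2 (within the scatter) and the step of a number 2.6 percentage points lower from compound 1 to compound 3 (within the scatter) both lie within the scatter, so no order among the three can be claimed.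

Compound 4 `Cc1cccc(/C=C2\CCC/C(=C\c3ccccc3)C2=O)c1` has not yet been measured. Its change from compound 1 is 3-methylphenyl in place of 4-fluorophenyl on a double-bonded chain carbon bound to a double-bonded ring carbon. Neither measured step concerns this exact swap; the two steps that do alter the same ring each stayed within the scatter. On that basis, compound 4 is expected to give 33%, with a range from 20% to 46%. The expected step of a number 1 percentage points lower from compound 1 to compound 4 (within the scatter) is estimated to stay within the scatter, in no definite direction.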

Compound 4, a percentage reported as inhibition, at one concentration (the size of the read-out at that concentration, not a potency): 47.9%
Compound 4: middle estimate off by 14.9 percentage points, on the low side, outside the stated range (above it).
By their numbers in this assay, from the lowest: compounds 3, 1 and 2 (each within the scatter of the next); then compound 4.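

In this assay, for the compounds shown here, putting 3-methylphenyl in place of 4-fluorophenyl gives a number 13.9 percentage points higher from compound 1 to compound 4 (beyond the scatter), the first step on this ring that lies beyond the scatter. The position on a double-bonded chain carbon bound to a double-bonded ring carbon can therefore respond to what it carries, even though the earlier changes on this ring stayed within the scatter. The two groups match in heavy atom count, hydrogen-bond donors and acceptors, and charge, so those counts do not separate them, and no measurement here explains the higher number.

This swap changes both the substituent and its place on the ring, so the methyl itself and its location cannot be told apart. From the compounds shown here alone, how the position responds to an ethyl group, a longer chain or an amine also stays open.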